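Methyl in Place of Trifluoromethyl on the Shared Core

This account rests on a few compounds, and the source may have more. Where it says the series, first, only, none or still open, it means among the compounds named here.

Measured compounds:
compound 1 `CNc1nc(C)c(C(=O)N/N=C/c2ccccc2C(F)(F)F)s1` — > 100 ug/mL
compound 2 `CN(C(=O)NC(=O)c1c(F)cccc1F)c1nc(C(F)(F)F)c(C(=O)N/N=C/c2ccc(C(F)(F)F)cc2)s1` — 49.6 ug/mL
compound 3 `CNc1nc(C(F)(F)F)c(C(=O)N/N=C/c2ccccc2C(F)(F)F)s1` — > 100 ug/mL

In a functional assay on HepG2 cells (Homo sapiens) for inhibition, read by MTT assay, with a stated time of 72 h (on this read-out lower numbers stand for stronger inhibition and higher numbers for weaker inhibition), compound 1 gives > 100 ug/mL, which is a limit of the assay. Compound 3 likewise gives > 100 ug/mL, a limit. Among the measured compounds shown here, compound 2 gives 49.6 ug/mL, the only number among the three. The change methyl in place of trifluoromethyl on an aromatic carbon is measured as a step that the two limits leave unreadable from compound 3 to compound 1, unreadable due to the limit of > 100 ug/mL in this assay, at which 2 of the 3 values shown sit. How the core of compound 2 differs from that of compound 3 is not broken down here.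

Compound 4 `Cc1nc(N(C)C(=O)NC(=O)c2c(F)cccc2F)sc1C(=O)N/N=C/c1ccc(C(F)(F)F)cc1` differs from compound 2 by methyl in place of trifluoromethyl on an aromatic carbon. Its surroundings differ from the earlier pair, where the ring atom two bonds away bears a methylamino group (2 heavy atoms) rather than a large group, so this is the same kind of change, not the same. With the earlier step unreadable, the expected step from compound 2 to compound 4 is a 1.0-fold higher number from compound 2 to compound 4 (0.00 log units; within the scatter). Compound 4 is therefore estimated at 50 ug/mL, between 20 ug/mL and 100 ug/mL.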

Compound 4, half-maximal inhibitory concentration: > 100 ug/mL
Compound 4 gave a limit, no number; the forecaster's own chance of this, stated with the estimate: 35%; at least 2.0-fold (0.30 log units) between middle value and limit.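

On the core of compound 2, methyl in place of trifluoromethyl gives an at least 2.0-fold higher number from compound 2 to compound 4 (0.30 log units; that floor lies within the scatter), so only a floor for the change is known and its true size is not. In this assay compound 4 gives > 100 ug/mL, which is a limit and not a number. The earlier step from compound 3 to compound 1 cannot be read, so the two steps cannot be compared, and whether the change carries the same size from one core to another stays unsettled, due to this: the limit of > 100 ug/mL in this assay, at which 3 of the 4 values shown sit.

Open, going by these compounds, is how an amine or a carboxylic acid would read in place of trifluoromethyl on the core of compound 2. Also open, on these data alone, is how methyl and trifluoromethyl compare on a core where both values fall clear of the limit.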